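Extending the Methoxy Group of Compound 2 to Benzyloxy

The source may report more compounds than this note shows. Statements on the series, on what has been measured and on what is new or still open speak of the compounds shown alone.

In an assay on microsomes for inhibition of acyl-CoA:cholesterol acyltransferase (Oryctolagus cuniculus) (on this read-out higher numbers stand for weaker inhibition and lower numbers for stronger inhibition), compound 2 `COc1cccc(C2(CNC(=O)Nc3c(C(C)C)cccc3C(C)C)CCCC2)c1` gives 13 nM, the lowest of the three numbers shown, though not all of them are separated from it beyond the scatter. Compound 1 `Cc1cccc(C2(CNC(=O)Nc3c(C(C)C)cccc3C(C)C)CCCC2)c1` gives 15 nM, and the step of a 1.2-fold lower number from compound 1 to compound 2 (0.06 log units; within the scatter) lies within the scatter. Compound 3 `COc1ccc(C2(CNC(=O)Nc3c(C(C)C)cccc3C(C)C)CCCC2)cc1` gives 31 nM, a step of a 2.4-fold higher number from compound 2 to compound 3 (0.38 log units; beyond the scatter). Compound 4 `CC(C)c1cccc(C(C)C)c1NC(=O)NCC1(c2cccc(OCc3ccccc3)c2)CCCC1` carries phenyl in place of hydrogen on a saturated chain carbon bound to an oxygen on an aromatic ring, so that methoxy becomes benzyloxy. No measured step adds a ring in this way; the two known steps, one small and one modest, give little reason to expect a large shift. The step to compound 4 is therefore expected to stay within the scatter: a 1.5-fold higher number from compound 2 to compound 4 (0.19 log units; within the scatter). Compound 4 is expected to give 20 nM, in the range 6 nM to 70 nM.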

Compound 4, half-maximal inhibitory concentration: 30 nM
The estimate for compound 4 lay 1.5-fold (0.18 log units) below the measured number; measured number inside the range.
By their numbers in this assay, from the lowest: compounds 2, 1, 4 and 3 (each within the scatter of the next, the first and the last beyond it).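

Extending methoxy to benzyloxy puts one more aromatic ring at this position, and in this assay that costs only a modest amount: a 2.3-fold higher number from compound 2 to compound 4 (0.36 log units; beyond the scatter). Set against the methyl group, the same extension gives a 2.0-fold higher number from compound 1 to compound 4 (0.30 log units; within the scatter), so a group this much larger still leaves compound 4 level with compound 1. Nothing available explains the shift from compound 2.

As far as these compounds go, it remains open how a hydroxyl, an ethoxy group or an amine would read at this place. Equally open, from the compounds shown here alone, is whether a substituent such as chlorine on the added phenyl would move the number.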